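The compounds below may be only part of what the source reports. "The series", "measured", "known", "first", "only" and "open" are said of these compounds alone.

Of the compounds shown here, three built on one shared core have been tested in a functional assay on NCI-H460 cells (Homo sapiens) for inhibition; on this read-out lower numbers stand for stronger inhibition of growth and higher numbers for weaker inhibition of growth. Compound 1 `COc1cc(/C=C/C(=O)c2cccc(-n3cc(-c4ccc(Cl)cc4)[nH]c3=O)c2)cc(OC)c1OC` gives 3740 nM, compound 2 `COc1cc(/C=C/C(=O)c2cccc(-n3cc(-c4ccccc4)[nH]c3=O)c2)cc(OC)c1OC` gives 1400 nM, and compound 3 `COc1ccc(-c2cn(-c3cccc(C(=O)/C=C/c4cc(OC)c(OC)c(OC)c4)c3)c(=O)[nH]2)cc1` gives 1560 nM. Compound 3 thus stands second highest of the three numbers, close to compound 2 and clearly apart from compound 1. Compound 4 `COc1cc(/C=C/C(=O)c2cccc(-n3cc(-c4cc(OC)c(OC)c(OC)c4)[nH]c3=O)c2)cc(OC)c1OC` carries 3,4,5-trimethoxyphenyl in place of 4-methoxyphenyl on an aromatic carbon. For the measured compounds named here, no measured pair swaps exactly these two groups. Of the measured steps, a 2.7-fold lower number from compound 1 to compound 2 (0.43 log units; beyond the scatter) and a 2.4-fold lower number from compound 1 to compound 3 (0.38 log units; beyond the scatter), while a 1.1-fold higher number from compound 2 to compound 3 (0.05 log units; within the scatter); adding one methoxy group changed little. Two further methoxy groups are expected to change little as well, so the expected step is a 1.0-fold lower number from compound 3 to compound 4 (0.02 log units; within the scatter), about the size of the scatter. In this assay compound 4 is estimated at 1500 nM, with a range from 600 nM to 4000 nM.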

Compound 4, concentration for 50% growth inhibition: 1730 nM
Compound 4: the middle estimate sits 1.2-fold (0.06 log units) below what was measured; low and high end bracket the measured number.
By their numbers in this assay, from the lowest: compounds 2, 3 and 4 (each within the scatter of the next); then compound 1.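

In this assay the 3,4,5-trimethoxyphenyl group gives a 1.1-fold higher number from compound 3 to compound 4 (0.04 log units; within the scatter) and a 1.2-fold higher number from compound 2 to compound 4 (0.09 log units; within the scatter) so the two further methoxy groups, and the full set of methoxy groups compared with plain phenyl, shift nothing beyond the scatter at this position. The 4-chlorophenyl group alone stands apart, with a 2.2-fold lower number from compound 1 to compound 4 (0.33 log units; beyond the scatter) as the step to the trimethoxy compound. Nothing available explains why these groups read alike. Open, going by these compounds, is whether a group of another kind on this ring, such as an amine or a carboxylic acid, would move the number beyond the scatter.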